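This account rests on a few compounds, and the source may have more. Where it says the series, first, only, none or still open, it means among the compounds named here.

Measured so far:
Compound 1 `Cc1nnc(-c2nn(-c3ccccc3)c(-c3ccccc3)c2C#N)c2cn(-c3ccccc3)nc12`: 9140 nM
Compound 2 `N#Cc1c(-c2nnc(O)c3nn(-c4ccc(Cl)cc4)cc23)nn(-c2ccccc2)c1-c1ccccc1`: > 100000 nM
Compound 3 `N#Cc1c(-c2nnc(-c3nn(-c4ccccc4)c(-c4ccccc4)c3C#N)c3nn(-c4ccc(Cl)cc4)cc23)nn(-c2ccccc2)c1-c1ccccc1`: 16000 nM

All three compounds were tested in a functional assay on T47D cells (Homo sapiens) for inhibition, read by sulforhodamine B assay, with a stated time of 48 h; on this read-out lower numbers stand for stronger inhibition of growth and higher numbers for weaker inhibition of growth. Compound 2 is known in this assay only through a limit, > 100000 nM, so no exact number exists for it. Compound 4 `N#Cc1c(-c2nnc(-c3ccccc3)c3nn(-c4ccc(Cl)cc4)cc23)nn(-c2ccccc2)c1-c1ccccc1` has not yet been measured in that test.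

Compound 4 differs from compound 2 at a single place. It has phenyl in place of hydroxy on an aromatic carbon of a six-membered aromatic ring with 2 nitrogen, part of a fused or bridged system of two rings: phenyl in place of hydroxy on an aromatic carbon.

For the measured compounds named here, no step between measured compounds shows what such a change does, so the expectation rests on the compounds with numerical values. Neither compound 1 nor compound 3 carries the hydroxy group, and in this assay compound 1 gives 9140 nM while compound 3 gives 16000 nM. Compound 4 is therefore expected to join them, and a large move toward stronger inhibition of growth is expected, though a result at the limit remains possible. The estimated change is an at least 8.3-fold lower number from compound 2 to compound 4 (0.92 log units; beyond the scatter). For compound 4 the expected value is 12000 nM, with an estimated range from 4000 nM to 40000 nM.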

Compound 4, concentration for 50% growth inhibition: 38000 nM
Estimate against measurement, compound 4: 3.2-fold (0.50 log units) below, and the stated range covers the measured number.
By their numbers in this assay, from the lowest: compounds 1 and 3 (each within the scatter of the next); then compound 4. At a limit, above all of these: compound 2.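

In this assay, for the compounds shown here, phenyl in place of hydroxy on an aromatic carbon of the six-membered aromatic ring with 2 nitrogen gives an at least 2.6-fold lower number from compound 2 to compound 4 (0.42 log units; beyond the scatter), and this is the first direct reading of any change at this position. The earlier compounds shown here offered no such step, whereas this pair isolates a single exchange and shows that the direction at this carbon is toward stronger inhibition of growth, with compound 4 reaching a measurable 38000 nM. The true size of the step stays unknown because compound 2 is known only through a limit: the limit of > 100000 nM in this assay, at which 1 of the 4 values shown sits.

The single step removes hydroxy and introduces phenyl at once, so the compounds shown cannot separate the loss of the one group from the arrival of the other. As far as these compounds go, how an amine, a methoxy group or a carboxylic acid on this same carbon would read in this assay remains open, as does whether a substituted phenyl ring would move the number further in either direction.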